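The compounds below may be only part of what the source reports. "The series", "measured", "known", "first", "only" and "open" are said of these compounds alone.

In a functional assay for antagonist activity, with Cavia porcellus as the target (a higher number here means a weaker inhibitor, a lower number a stronger inhibitor), compound 1 `CCN(CC)CC#CCCC1(C(O)(c2ccccc2)c2ccccc2)SCCCS1` gives 500 nM; 500 nM (2 entries) for both entries, compound 2 `CN(CC#CCCC1(C(O)(c2ccccc2)c2ccccc2)SCCCS1)CCCc1ccccc1` gives 1630 nM and compound 3 `CN(C)CC#CCCC1(C(O)(c2ccccc2)c2ccccc2)SCCCS1` gives 1810 nM on the same shared core. Compound 3 therefore stands level with compound 2 within the scatter, and its value is a higher number than that of compound 1.

The next change leads to compound 4 `OC(c1ccccc1)(c1ccccc1)C1(CCC#CCN2CCCCC2)SCCCS1`, with piperidin-1-yl in place of dimethylamino on a saturated chain carbon bound to a triple-bonded carbon. Among the measured compounds shown here, the only measured step at this amine, a 1.1-fold higher number from compound 2 to compound 3 (0.05 log units; within the scatter), stays within the scatter. For the measured compounds named here, compound 1 at 500 nM; 500 nM (2 entries) shows that a different amine substitution can go with a lower number, but no measured compound carries the piperidine ring. A modest move towards a lower number in this assay is therefore expected, and no change beyond the scatter remains possible.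

The expected size is a 2.6-fold lower number from compound 3 to compound 4 (0.41 log units; beyond the scatter) as an estimate. For compound 4 the estimated value is 700 nM with an expected range from 250 nM to 1800 nM in this series.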

Compound 4, antagonist equilibrium constant: 1000 nM
The estimate for compound 4 lay 1.4-fold (0.15 log units) below the measured number, and the stated range covers the measured number.
By their numbers in this assay, from the lowest: compounds 4, 2 and 3 (each within the scatter of the next).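

In this assay, piperidin-1-yl in place of dimethylamino on a saturated chain carbon bound to a triple-bonded carbon gives a 1.8-fold lower number from compound 3 to compound 4 (0.26 log units; within the scatter), and piperidin-1-yl in place of methyl(3-phenylpropyl)amino gives a 1.6-fold lower number from compound 2 to compound 4 (0.21 log units; within the scatter). This position therefore accepts a six-membered non-aromatic ring in place of either open-chain amine, and neither step separates the ring compound from its open-chain partner in this assay. No supporting information bears on this result.

Open, from the compounds shown here alone, is how a pyrrolidin-1-yl or morpholin-4-yl group at this position would compare with piperidin-1-yl. Among the compounds shown here, also open is how compound 4 relates to compound 1 , which carries diethylamino and gives 500 nM; 500 nM (2 entries), since no step between the two can be read here.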